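This account rests on a few compounds, and the source may have more. Where it says the series, first, only, none or still open, it means among the compounds named here.

Compound 2 `C=CCc1cc2c(cc1O)CC(CCc1ccccc1)O2`: 17 nM
Compound 3 `C=CCc1c(O)ccc2c1CC(CCc1ccccc1)O2`: 25 nM
Compound 1 `CCCc1cc2c(cc1O)C(C)(C)C(CCc1ccc(SC)cc1)O2`: 92 nM

All three were tested in an assay for inhibition of Polyunsaturated fatty acid 5-lipoxygenase (Rattus norvegicus); on this read-out lower numbers stand for stronger inhibition and higher numbers for weaker inhibition. Compound 2 has the lowest number of the three, but compound 3 lies within the usual scatter of it, so these two cannot be told apart. Compound 1 lies beyond the scatter, so it is clearly the weaker inhibitor of the pair with compound 2. Within the data shown here, none of the measured compounds differ from another in only one place, so no measured single-step size is available to lean on.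

Compound 4 `Oc1cc2c(cc1CCCSc1ccncc1)OC(CCc1ccccc1)C2` differs from compound 2 in one place: 2-((pyridin-4-yl)sulfanyl)ethyl in place of vinyl on a saturated chain carbon bound to an aromatic carbon. Among the measured compounds shown here, a change of this kind has no counterpart among the measured compounds, so its direction is uncertain. A modest step toward a higher number is expected, a 2.4-fold higher number from compound 2 to compound 4 (0.37 log units; beyond the scatter), though it may well stay within the scatter. Compound 4 is therefore estimated at 40 nM, with a range from 8 nM to 200 nM.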

Compound 4, half-maximal inhibitory concentration: 8 nM
For compound 4 the middle estimate is 5.0-fold (0.70 log units) above the measured one, and the stated range covers the measured number.
By their numbers in this assay, from the lowest: compound 4; then compounds 2 and 3 (each within the scatter of the next); then compound 1.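

This position, on a saturated chain carbon bound to an aromatic carbon, accepts a far larger group with no loss of inhibition: in this assay, 2-((pyridin-4-yl)sulfanyl)ethyl in place of vinyl gives a 2.1-fold lower number from compound 2 to compound 4 (0.33 log units; beyond the scatter). The entering group has 9 heavy atoms against 2 for the one that leaves, and it brings a six-membered aromatic ring with 1 hetero atom, so a big change here can still lower the number. No measurement at hand explains this gain.

The compounds shown do not separate the contributions of the pyridine ring, the sulfur and the chain, so a phenyl ring in place of the pyridine, or an oxygen in place of the sulfur, would be informative. On these data alone, whether an amine or a longer chain at this position would keep the number as low also remains open.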